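Trading a methyl for hydrogen on the aromatic oxygen

The source may report more compounds than this note shows. Statements on the series, on what has been measured and on what is new or still open speak of the compounds shown alone.

compound 1: `O=C1N/C(=N\c2nc3ccccc3s2)S/C1=C\c1ccc([N+](=O)[O-])cc1` — 57%
compound 2: `COc1ccc(/C=C2\S/C(=N/c3nc4ccccc4s3)NC2=O)cc1` — 37.8%

In a functional assay on the whole organism (strain AKR) for inhibition, with Mus musculus as the target, read by paw edema, with a stated time of 3.5 h, at a dose of 0.1 mmol/kg by the intraperitoneal route, in the presence of a further agent that is not named here (on this read-out higher numbers stand for more inhibition at the one dose given (going by the name of the read-out) and lower numbers for less inhibition), compound 1 gives 57%, while compound 2 gives 37.8%. Among the measured compounds shown here, compound 2 therefore stands lowest of the two numbers, and its only neighbour is compound 1, from which it is separated by the step of a number 19.2 percentage points lower from compound 1 to compound 2 (beyond the scatter), a modest fall that lies beyond the scatter. Compound 3 `O=C1N/C(=N\c2nc3ccccc3s2)S/C1=C\c1ccc(O)cc1` differs from compound 2 in one place: hydrogen in place of methyl on an oxygen on an aromatic ring. For the measured compounds named here, no measured step covers this exchange; the single step recorded concerns nitro against methoxy, not methoxy against hydroxy, so it bears on compound 3 only loosely, as a sign that a change at this aromatic position can move this assay by a modest amount. Compound 3 is therefore expected to sit close to compound 2, with a step of a number 2.2 percentage points higher from compound 2 to compound 3 (within the scatter) that is not expected to exceed the scatter. The estimate for compound 3 in this assay is 40%, within a range from 25% to 56%.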

Compound 3, a percentage reported as inhibition, in the whole organism at one dose (the size of the read-out at that dose, not a potency): 68.7%
For compound 3 the middle estimate is 28.7 percentage points below the measured one, outside the stated range (above it).
By their numbers in this assay, from the lowest: compound 2; then compound 1; then compound 3.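

In this assay hydrogen in place of methyl on an oxygen on an aromatic ring gives a number 30.9 percentage points higher from compound 2 to compound 3 (beyond the scatter) and so counts as a large step, which shows that the methyl alone weighs heavily here, more than the modest a number 19.2 percentage points lower from compound 1 to compound 2 (beyond the scatter) had suggested for this place. Hydroxy in place of nitro gives a number 11.7 percentage points higher from compound 1 to compound 3 (beyond the scatter) and thereby reverses what the first pair hinted at: an oxygen-linked group here does not by itself lower the number, since methoxy and hydroxy stand at opposite ends of the three. Nothing available explains why this single methyl matters so much.

On these data alone, whether an amine, a carboxylic acid or a longer chain on the oxygen, such as ethoxy, would follow hydroxy or methoxy stays open. As far as these compounds go, since each number is the size of the effect at one dose, how these compounds compare in potency also stays open.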